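A few compounds are considered here, and "the series" means these few. Any claim that something is new, unique, unknown or untested is made for them only; others in the source may bear on it.

Measured compounds:
- compound 1 `COc1cc(N2C(N)=C(C#N)C(c3ccc([N+](=O)[O-])cc3)C3=C2CC(C)(C)CC3=O)cc(OC)c1OC` — a functional assay on Ehrlich cells (Mus musculus) for cytotoxicity, tested at 25 ug/mL; on this read-out lower numbers stand for a weaker effect and higher numbers for a stronger effect at the one concentration tested: 50%
- compound 2 `COc1cc(N2C(N)=C(C#N)C(/C=C/c3ccccc3)C3=C2CC(C)(C)CC3=O)cc(OC)c1OC` — this assay: 30%
- compound 3 `COc1cc(N2C(N)=C(C#N)C(c3ccc(C)cc3)C3=C2CC(C)(C)CC3=O)cc(OC)c1OC` — this assay: 50%

Compound 3 stands level with compound 1, the two together the highest of the three numbers (no change at the digits printed from compound 1 to compound 3 (within the scatter)), and above compound 2 (a number 20 percentage points higher from compound 2 to compound 3 (beyond the scatter)). Compound 4 `COc1cc(N2C(N)=C(C#N)C(c3cccs3)C3=C2CC(C)(C)CC3=O)cc(OC)c1OC` remains to be measured; it differs from compound 3 as follows: thiophen-2-yl in place of 4-methylphenyl on a saturated ring carbon. For the measured compounds named here, two steps concern the same saturated ring carbon: a number 20 percentage points lower from compound 1 to compound 2 (beyond the scatter) and a number 20 percentage points higher from compound 2 to compound 3 (beyond the scatter), both modest, whereas a swap on the aromatic ring left the number flat (no change at the digits printed from compound 1 to compound 3 (within the scatter)). Thiophen-2-yl, like 4-methylphenyl, is an aromatic ring, unlike 2-phenylethenyl; no thiophen-2-yl compound has been measured in this series. A step in this assay within the scatter, or a small loss, is expected: a number 5 percentage points lower from compound 3 to compound 4 (within the scatter). Compound 4 is estimated at 45%, range 30% to 60%.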

Compound 4, a percentage reported as activity, at one concentration (the size of the read-out at that concentration, not a potency): 10%
For compound 4 the middle estimate is 35 percentage points above the measured one; the whole stated range lies above it.
By their numbers in this assay, from the lowest: compound 4; then compound 2; then compounds 1 and 3 (each within the scatter of the next).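

In this assay the saturated ring carbon proves sensitive to which aromatic ring it carries: thiophen-2-yl gives (a number 40 percentage points lower from compound 3 to compound 4 (beyond the scatter)) and (a number 40 percentage points lower from compound 1 to compound 4 (beyond the scatter)), so an aromatic ring at this carbon does not by itself keep the number up. The same group also falls short of the non-aromatic 2-phenylethenyl (a number 20 percentage points lower from compound 2 to compound 4 (beyond the scatter)). No measurement here explains these losses.

Still open, on these data alone, is whether the low number belongs to the sulfur or to the five-membered ring. Furan-2-yl, thiophen-3-yl or phenyl at this carbon would separate the two.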